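Amide in Place of the Acid of Compound 2

The compounds below may be only part of what the source reports. "The series", "measured", "known", "first", "only" and "open" are said of these compounds alone.

Compound 1 `COc1ccc(/C=C\c2cc(OC)c(OC)c(OC)c2)cc1OCc1ccc(CN2CC(C(=O)O)C2)cc1` carries a 3-carboxyazetidin-1-yl group on a saturated chain carbon bound to an aromatic carbon. In a functional assay on B16-F10 cells (Mus musculus) for antiproliferative activity, read by CCK-8 assay, with a stated time of 48 h (on this read-out higher numbers stand for weaker inhibition and lower numbers for stronger inhibition), compound 1 reports only a limit, > 10000 nM. Compound 2 `COc1ccc(/C=C\c2cc(OC)c(OC)c(OC)c2)cc1OCc1ccc(CN2CCCCC2C(=O)O)cc1` has 2-carboxypiperidin-1-yl in that place. In this assay compound 2 likewise reports only a limit, > 10000 nM. The step that the two limits leave unreadable from compound 1 to compound 2 is unreadable, as both values sit at the limit (the limit of > 10000 nM in this assay, at which 2 of the 2 values shown sit). Compound 3 `COc1ccc(/C=C\c2cc(OC)c(OC)c(OC)c2)cc1OCc1ccc(CN2CCCCC2C(=O)NCCNC(=O)OC(C)(C)C)cc1` differs from compound 2 by (2-((tert-butoxycarbonyl)amino)ethyl)amino in place of hydroxy on a carbonyl carbon. Among the measured compounds shown here, no measured step bears on this change: the single step available gives neither size nor direction, and compound 2 stands only at a limit. The step of an at least 1.1-fold lower number from compound 2 to compound 3 (0.04 log units; that floor lies within the scatter) is therefore expected to stay within the scatter, and the assay may again return a limit for compound 3. Compound 3 is expected at 9000 nM, in the range 1500 nM to 40000 nM.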

Compound 3, half-maximal inhibitory concentration: 4700 nM
Beside the measured number, compound 3's estimate is 1.9-fold (0.28 log units) above it; measured number inside the range.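

Replacing hydroxy on the carbonyl carbon with (2-((tert-butoxycarbonyl)amino)ethyl)amino gives an at least 2.1-fold lower number from compound 2 to compound 3 (0.32 log units; beyond the scatter) in this assay. Among the compounds shown here, this is the first step with a readable direction, and compound 3 shows that a free carboxylic acid at this place is not required for a numerical value on this read-out. The size of the step remains only a floor, since the starting value is not a number: the limit of > 10000 nM in this assay, at which 2 of the 3 values shown sit.

The compounds shown do not separate the contribution of the amide link from that of the tert-butoxycarbonyl end, a question that a simple methyl amide or a free primary amine at the end of the ethyl chain would address. From the compounds shown here alone, whether the same amide would have a similar effect on the 3-carboxyazetidin-1-yl group of compound 1 also remains open.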